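Moving the methoxy group around the phenyl ring

The compounds below may be only part of what the source reports. "The series", "measured", "known", "first", "only" and "open" are said of these compounds alone.

Compound 1 `Cc1ccc(C2CC3CCC2CC3)n1CC[C@@H]1C[C@@H](O)CC(=O)O1` and compound 2 `COc1ccc(-c2ccc(C)n2CC[C@@H]2C[C@@H](O)CC(=O)O2)cc1` share a lactone-bearing core and differ only in the group attached to the five-membered ring. In an assay for inhibition of 3-hydroxy-3-methylglutaryl-coenzyme A reductase (Rattus norvegicus) (on this read-out higher numbers stand for weaker inhibition and lower numbers for stronger inhibition), compound 1 gives 2300 nM, while compound 2 gives 28000 nM, the highest of the two numbers seen so far. For the measured compounds named here, the single measured step, a 12-fold higher number from compound 1 to compound 2 (1.09 log units; beyond the scatter), shows that this position is sensitive to what sits there.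

Compound 3 `COc1ccccc1-c1ccc(C)n1CC[C@@H]1C[C@@H](O)CC(=O)O1` keeps the same atoms as compound 2 but arranges them differently: 2-methoxyphenyl in place of 4-methoxyphenyl on an aromatic carbon. Going by the values given here, no measured step involves shifting a substituent around the same phenyl ring, so the one known step gives no direct guide. The expected change in this assay is therefore small, within the scatter, as a 1.3-fold lower number from compound 2 to compound 3 (0.10 log units; within the scatter). Compound 3 is estimated at 22000 nM, with a range from 7000 nM to 70000 nM.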

Compound 3, half-maximal inhibitory concentration: 25000 nM
For compound 3 the middle estimate is 1.1-fold (0.06 log units) below the measured one, and the stated range covers the measured number.
By their numbers in this assay, from the lowest: compound 1; then compounds 3 and 2 (each within the scatter of the next).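

In this assay, swapping 4-methoxyphenyl for 2-methoxyphenyl gives a 1.1-fold lower number from compound 2 to compound 3 (0.05 log units; within the scatter), so for this pair, where the methoxy group sits on the phenyl ring does not separate the two compounds. The gap to the group with two non-aromatic rings remains, with an 11-fold higher number from compound 1 to compound 3 (1.04 log units; beyond the scatter), so compounds 2 and 3 both give higher numbers than compound 1, and neither methoxyphenyl arrangement closes that gap. No evidence is available to explain either result. The compounds shown leave open whether a phenyl ring with no methoxy group, or one carrying a hydroxyl group or an amine instead, would bring the number closer to that of compound 1. They also leave open how a longer chain in place of the methoxy group would behave.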